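Trifluoromethoxy for trifluoromethyl on the aryl ether

The source may hold more compounds than are shown below. What is called first, only, known or untested is meant among the compounds shown, and "the series" means these compounds.

Three compounds of the series have numbers in a functional assay on CRL2813 cells (Homo sapiens) for antiproliferative activity, read by sulforhodamine B assay, with a stated time of 3 days, in the presence of a further agent that is not named here; on this read-out higher numbers stand for weaker inhibition and lower numbers for stronger inhibition. Compound 3 `O=C(Nc1cccc(C(F)(F)F)c1)N[C@H]1CC[C@H](Oc2ccc(C(F)(F)F)cc2)CC1` gives 660 nM, the lowest of the three. Compound 1 `O=C(Nc1cccc(C(F)(F)F)c1)N[C@H]1CC[C@H](Oc2cccc(C(F)(F)F)c2)CC1` gives 1050 nM; the step of a 1.6-fold lower number from compound 1 to compound 3 (0.20 log units; within the scatter) is within the scatter, so compounds 1 and 3 cannot be ordered. Compound 2 `O=C(Nc1cccc(C(F)(F)F)c1)N[C@H]1CC[C@@H](Oc2ccc(F)cc2)CC1` gives 6000 nM, a number well above that of compound 3, beyond the scatter.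

Compound 4 `O=C(Nc1cccc(C(F)(F)F)c1)N[C@H]1CC[C@H](Oc2ccc(OC(F)(F)F)cc2)CC1` is still to be measured. It differs from compound 3 by trifluoromethoxy in place of trifluoromethyl on an aromatic carbon. Among the measured compounds shown here, no measured step swaps one group for another at that position. For the measured compounds named here, the only single-point step in hand, a 1.6-fold lower number from compound 1 to compound 3 (0.20 log units; within the scatter), moved a trifluoromethyl from one position on the aryl ether to another and stayed within the scatter, which gives no basis for expecting a sizeable shift here. The estimate for compound 4 is therefore a step of no more than the usual spread, a 1.2-fold higher number from compound 3 to compound 4 (0.08 log units; within the scatter), with the direction not determinable from the data. Compound 4 is estimated at 800 nM, expected to fall between 300 nM and 2500 nM.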

Compound 4, half-maximal inhibitory concentration: 850 nM
For compound 4 the middle estimate is 1.1-fold (0.03 log units) below the measured one; the measured number falls inside the stated range.
By their numbers in this assay, from the lowest: compounds 3, 4 and 1 (each within the scatter of the next); then compound 2.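

Among the compounds shown here, the step of a 1.3-fold higher number from compound 3 to compound 4 (0.11 log units; within the scatter) is the first exchange of one group for another at this position, on an aromatic carbon para to a large group, in this assay. The earlier single-point step only moved trifluoromethyl around the aryl ether, whereas this one inserts an oxygen between the ring and the fluorinated carbon, and the number stays within the scatter of that of compound 3. No measurement is at hand that could account for these two groups reading alike.

The compounds shown leave open how an amine, a carboxylic acid or a longer chain on this aromatic carbon would read in this assay. They also leave open whether trifluoromethoxy would read the same in place of the other trifluoromethyl, the one on the shared core.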